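Aryl urea pyrazoles: removing one trifluoromethyl from compound 3

A few compounds are considered here, and "the series" means these few. Any claim that something is new, unique, unknown or untested is made for them only; others in the source may bear on it.

Three compounds of the series share one core and differ in the aryl urea end. Compound 1 `O=C(Nc1cccc(-n2cc(-c3ccncc3)c(-c3cc(O)cc(Cl)c3)n2)c1)Nc1ccc(Cl)c(C(F)(F)F)c1` gives 95% in a functional assay on PC-3 cells (Homo sapiens) for inhibition, read by sulforhodamine B assay, with a stated time of 48 h, tested at 0.01 uM; on this read-out lower numbers stand for a stronger effect and higher numbers for a weaker effect at the one concentration tested. Compound 2 `O=C(Nc1cccc(-n2cc(-c3ccncc3)c(-c3cc(O)cc(Cl)c3)n2)c1)Nc1ccc(Cl)c(Cl)c1` gives 90% in this assay; the step of a number 5 percentage points lower from compound 1 to compound 2 (within the scatter) is small. Compound 3 `COc1cc(Cl)cc(-c2nn(-c3cccc(NC(=O)Nc4cc(C(F)(F)F)cc(C(F)(F)F)c4)c3)cc2-c2ccncc2)c1` gives 101% in this assay, the highest of the three numbers: compound 1 sits nearest, six points lower and within the scatter, compound 2 furthest, lower by an amount beyond the scatter.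

Compound 4 `COc1cc(Cl)cc(-c2nn(-c3cccc(NC(=O)Nc4cccc(C(F)(F)F)c4)c3)cc2-c2ccncc2)c1` differs from compound 3 in one place: hydrogen in place of trifluoromethyl on an aromatic carbon. Going by the values given here, the one measured step that touches the same aryl urea end, from compound 1 to compound 2, swaps a trifluoromethyl for chloro and stays within the scatter. On that basis no step beyond the scatter is expected for this assay here either, the direction being open. Compound 4 is therefore estimated at 97%, with a range of 85% to 108%, which means an expected step of a number 4 percentage points lower from compound 3 to compound 4 (within the scatter).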

Compound 4, a percentage reported as activity, at one concentration (the size of the read-out at that concentration, not a potency): 91%
For compound 4 the middle estimate is 6 percentage points above the measured one; the measured number falls inside the stated range.
By their numbers in this assay, from the lowest: compounds 2, 4, 1 and 3 (each within the scatter of the next, the first and the last beyond it).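

In this assay, going by these compounds alone, the step of a number 10 percentage points lower from compound 3 to compound 4 (within the scatter) is the first in this set where a group leaves the aryl urea end outright, with only hydrogen entering, rather than being swapped for another substituent. Losing the trifluoromethyl and its 4 heavy atoms from this place on the six-membered aromatic ring therefore produces no step beyond the scatter, so at the one concentration tested the read-out does not depend on this group being present. No measurement here explains this result.

Still open, on these data alone, is whether an amine or a carboxylic acid at this place would give a step beyond the scatter, and what replacing the remaining trifluoromethyl with hydrogen would do. Also open, as far as these compounds go, is whether the same change reads alike on the core of compound 1, or at any other concentration.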